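The compounds below may be only part of what the source reports. "The series", "measured", "known", "first", "only" and "open" are said of these compounds alone.

Measured compounds:
compound 1 `CCCCCCCCCCCCCCCCOP(=O)(O)OCCSC(=S)N1CCN(C)CC1` — > 100000 nM
compound 2 `CCCCCCOP(=O)(O)OCCSC(=S)N1CCCCC1` — 85000 nM
compound 3 `CCCCCCCCCCCCCCCCOP(=O)(O)OCCSC(=S)N1CCCCC1` — 100000 nM

All three values come from a functional assay on MDA-MB-231 cells (Homo sapiens) for inhibition, read by MTT assay, with stated times of 18 h and 4 h; a lower number here means a stronger inhibitor, a higher number a weaker inhibitor. The reading for compound 1 is a limit of the assay, not a number (the limit of > 100000 nM in this assay, at which 1 of the 3 values shown sits). Compound 2 and compound 3 differ only in the chain, (hydrogen in place of decyl on a saturated chain carbon, six bonds along the chain from an oxygen on an unsaturated carbon), and the step of a 1.2-fold higher number from compound 2 to compound 3 (0.07 log units; within the scatter) is within the scatter. Compound 3 and compound 1 differ by 4-methylpiperazin-1-yl in place of piperidin-1-yl on a thiocarbonyl carbon, giving a number no lower from compound 3 to compound 1 (the limit leaves the size open). Compound 4 `CCCCCCOP(=O)(O)OCCSC(=S)N1CCN(C)CC1` is not yet measured and carries the same change on the core of compound 2: 4-methylpiperazin-1-yl in place of piperidin-1-yl on a thiocarbonyl carbon. The expected step, a 1.2-fold higher number from compound 2 to compound 4 (0.07 log units; within the scatter), rests on a number no lower from compound 3 to compound 1 (the limit leaves the size open) and on compound 2 standing at 85000 nM. Compound 4 is estimated at 100000 nM, expected between 55000 nM and 250000 nM, with a fair chance that only a limit is returned.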

Compound 4, half-maximal inhibitory concentration: 73000 nM
Compound 4: middle estimate off by 1.4-fold (0.14 log units), on the high side; low and high end bracket the measured number.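

In this assay, 4-methylpiperazin-1-yl in place of piperidin-1-yl gives a 1.2-fold lower number from compound 2 to compound 4 (0.07 log units; within the scatter), and hydrogen in place of decyl on the chain gives an at least 1.3-fold lower number from compound 1 to compound 4 (0.13 log units; that floor lies within the scatter). The reading for compound 1, > 100000 nM, is a limit of the assay. The ring change therefore has a readable size on one core only, and the comparison shows neither that it carries over to the other core nor that it does not: the same change on two cores in this assay, a number no lower (the limit leaves the size open) from compound 3 to compound 1 and a 1.2-fold lower number (0.07 log units; within the scatter) from compound 2 to compound 4; the limit leaves it open whether they differ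

Still open, on these data alone, is whether a morpholin-4-yl group on the thiocarbonyl carbon, or a carboxylic acid at the end of the chain, would give a step beyond the scatter in this assay.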